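Notes on a three-compound set and one unmeasured analogue

The compounds below may be only part of what the source reports. "The series", "measured", "known", "first", "only" and "open" are said of these compounds alone.

Measured so far, in a functional assay on MCF7 cells (Homo sapiens) for inhibition, read by MTT assay, with a stated time of 48 h; on this read-out higher numbers stand for weaker inhibition and lower numbers for stronger inhibition:
- compound 1 `CCOC(=O)C1=C(N/C=N/c2ncc(-c3ccccc3)s2)Nc2[nH]nc(C)c2C1c1ccc(N(C)C)cc1` gives 10100 nM
- compound 2 `CCOC(=O)C1=C(N/N=C(/Cl)C#N)Nc2[nH]nc(C)c2C1c1ccc(N(C)C)cc1` gives 23200 nM
- compound 3 `CCOC(=O)C1=C(N/N=C(/C(=O)Br)c2ccc(Cl)cc2)Nc2[nH]nc(C)c2C1c1ccc(N(C)C)cc1` gives 46300 nM

Compound 2 stands second highest of the three numbers in this assay. Its nearest neighbour is compound 3, reached by a 2.0-fold higher number from compound 2 to compound 3 (0.30 log units; within the scatter); the furthest is compound 1, whose number is lower by an amount beyond the scatter. The set is too small to support any pattern.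

Compound 4 `CCOC(=O)C(=NNC1=C(C(=O)OCC)C(c2ccc(N(C)C)cc2)c2c(C)n[nH]c2N1)C(=O)OCC` has not yet been measured. It differs from compound 2 in one place: a group of 12 heavy atoms (7 carbon, 1 nitrogen, 4 oxygen; no ring) in place of a group of 5 heavy atoms (2 carbon, 2 nitrogen, 1 chlorine; no ring), on an amine nitrogen.

Among the compounds with values here, the only measured step that bears on this is the one from compound 2 to compound 3, which also exchanges the group of 5 heavy atoms on the amine nitrogen for a group of 12 heavy atoms, and that step was a 2.0-fold higher number from compound 2 to compound 3 (0.30 log units; within the scatter), within the scatter. The group entering in compound 4 has no ring and carries more oxygen, so the comparison is loose, but nothing measured here points to a change beyond the scatter.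

Compound 4 is therefore expected to sit close to compound 2, with an estimated step of a 1.3-fold higher number from compound 2 to compound 4 (0.11 log units; within the scatter) in this assay. The estimate for compound 4 is 30000 nM, with a range from 10000 nM to 90000 nM.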

Compound 4, half-maximal inhibitory concentration: 89800 nM
Compound 4: middle estimate off by 3.0-fold (0.48 log units), on the low side, and the stated range covers the measured number.
By their numbers in this assay, from the lowest: compound 1; then compounds 2, 3 and 4 (each within the scatter of the next, the first and the last beyond it).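

In this assay, the exchange on the amine nitrogen whose other neighbour is the double-bonded ring carbon now gives a step beyond the scatter: a 3.9-fold higher number from compound 2 to compound 4 (0.59 log units; beyond the scatter), with the group of 12 heavy atoms (7 carbon, 1 nitrogen, 4 oxygen; no ring) in place of the group of 5 heavy atoms (2 carbon, 2 nitrogen, 1 chlorine; no ring), whereas the earlier exchange at this position stayed within it at a 2.0-fold higher number from compound 2 to compound 3 (0.30 log units; within the scatter). The two larger groups are not separated, at a 1.9-fold higher number from compound 3 to compound 4 (0.29 log units; within the scatter), so the group with one six-membered aromatic ring of carbon only and the group with no ring cannot be told apart at this position. No measurement shown here accounts for the step.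

The compounds shown leave open whether the step follows the heavy-atom count of the entering group or its particular atoms, since the two larger groups have equal counts and the set holds only one smaller group. Also open, as far as these compounds go, is how a carboxylic acid or a simple amine on this nitrogen would read out against the present groups.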